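Adding a Second Methoxy Group to Compound 2

A few compounds are considered here, and "the series" means these few. Any claim that something is new, unique, unknown or untested is made for them only; others in the source may bear on it.

Three compounds sharing one core were tested in a functional assay on U-87MG ATCC cells for antiproliferative activity against U-87 MG (Homo sapiens), read by MTT assay, with a stated time of 48 h, tested at 10 uM; on this read-out lower numbers stand for a stronger effect and higher numbers for a weaker effect at the one concentration tested. Compound 1 `COc1ccc(-c2nc(C)c(C(=O)CSc3nc(-c4ccc(OC)cc4)c(C#N)c(=O)[nH]3)s2)cc1` gives 80.3%, compound 2 `COc1cccc(-c2nc(SCC(=O)c3sc(-c4ccccc4)nc3C)[nH]c(=O)c2C#N)c1` gives 90.2%, and compound 3 `COc1ccc(-c2nc(SCC(=O)c3sc(-c4ccc(Cl)cc4)nc3C)[nH]c(=O)c2C#N)cc1` gives 88.3%. Compound 2 stands at the top of these three numbers, but its gaps to compound 3 and to compound 1 are both within the scatter of this kind of measurement, so the three compounds cannot be told apart on the numbers shown. Within the data shown here, the one single-point comparison available, a number 8 percentage points higher from compound 1 to compound 3 (within the scatter), likewise stays within the scatter.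

Compound 4 `COc1ccc(-c2nc(SCC(=O)c3sc(-c4ccccc4)nc3C)[nH]c(=O)c2C#N)cc1OC` differs from compound 2 by methoxy in place of hydrogen on an aromatic carbon. Cut one bond further out, the change reads 3-methoxyphenyl to 3,4-dimethoxyphenyl, and the new group sits ortho to a methoxy group and para to a large group on that ring. Among the measured compounds shown here, no measured pair shows exactly this change; the step from compound 1 to compound 3 concerns the same ring in another arrangement and left the number where it was. With only a change within the scatter to lean on, the step of a number 3.2 percentage points lower from compound 2 to compound 4 (within the scatter) is expected to stay within the scatter as well. Compound 4 is therefore estimated to give 87% in this assay, between 74% and 98%.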

Compound 4, a percentage reported as activity, at one concentration (the size of the read-out at that concentration, not a potency): 69.8%
The estimate for compound 4 lay 17.2 percentage points above the measured number; the whole stated range lies above it.
By their numbers in this assay, from the lowest: compound 4; then compounds 1, 3 and 2 (each within the scatter of the next).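

The change from 3-methoxyphenyl to 3,4-dimethoxyphenyl is the first step among these compounds to go beyond the scatter: in this assay there is a number 20.4 percentage points lower from compound 2 to compound 4 (beyond the scatter). Among these compounds, one added methoxy group, ortho to a methoxy group and para to a large group, is therefore enough to set compound 4 apart from compound 2, whereas the only earlier step, between compound 1 and compound 3, stayed within the scatter. The read-out is the size of the effect at one concentration, so this shows a stronger effect at that concentration rather than a measured potency, and nothing available explains how the added group produces it.

From the compounds shown here alone, what a hydroxyl group, an amine or an ethoxy group would do at this same position remains open, so it cannot yet be said whether the effect is particular to methoxy. Also open, going by these compounds, is whether the added methoxy group would give a similar step in a compound carrying the chloro group of compound 3, since a single pair cannot show how far this change carries across the series.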